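Swapping the Azole on the Benzylic Carbon

The source may hold more compounds than are shown below. What is called first, only, known or untested is meant among the compounds shown, and "the series" means these compounds.

Two agonists have been measured in a functional assay on A9 cells for agonist activity at Free fatty acid receptor 1 (Homo sapiens), read by inositol phosphate accumulation; on this read-out lower numbers stand for an effect already at smaller amounts and higher numbers for an effect only at larger amounts of compound. Compound 1 `Cc1cc(Cl)ccc1-c1cccc(COc2ccc([C@H](CC(=O)O)c3nccn3C)cc2)c1` gives 7.6 nM in this assay. Among the compounds with values here, compound 2 `Cc1nc(-c2ccc(C(F)(F)F)cc2)sc1COc1ccc([C@H](CC(=O)O)c2nccn2C)cc1` gives 16 nM in this assay, the higher of the two numbers; the gap between compound 2 and compound 1 lies beyond the usual scatter of repeated measurements, so compound 2 is the one of the pair that needs more material for a half-maximal response.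

Compound 3 `Cc1nc(-c2ccc(C(F)(F)F)cc2)sc1COc1ccc([C@H](CC(=O)O)c2cnco2)cc1` keeps everything in compound 2 except one group: 1,3-oxazol-5-yl in place of 1-methyl-1H-imidazol-2-yl on a saturated chain carbon bound to an aromatic carbon and a saturated chain carbon. Within the data shown here, no measured pair in this set isolates this change, so there is no directly comparable step to lean on.

Without such a reference, the direction can only be estimated. The expectation is that compound 3 will require somewhat more material than compound 2, an expected step of a 2.5-fold higher number from compound 2 to compound 3 (0.40 log units; beyond the scatter) in this assay, modest and possibly no larger than the scatter. Compound 3 is therefore estimated at 40 nM in this assay, within a range from 12 nM to 150 nM.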

Compound 3, half-maximal effective concentration: 9 nM
Compound 3: middle estimate off by 4.4-fold (0.65 log units), on the high side; the whole stated range lies above it.
By their numbers in this assay, from the lowest: compounds 1, 3 and 2 (each within the scatter of the next, the first and the last beyond it).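

In this assay, putting 1,3-oxazol-5-yl in place of 1-methyl-1H-imidazol-2-yl on a saturated chain carbon bound to an aromatic carbon and a saturated chain carbon gives a 1.8-fold lower number from compound 2 to compound 3 (0.25 log units; within the scatter) and so leaves the two compounds indistinguishable on this read-out. This is the first change at this position in the compounds shown, and it indicates that 1-methyl-1H-imidazol-2-yl is not required there for agonist activity at this level: a different five-membered aromatic ring with two hetero atoms, one heavy atom smaller and carrying an oxygen in place of one nitrogen, serves equally well within the scatter. No measured information on the two rings accounts for this outcome.

From the compounds shown here alone, what remains open is how a pyridine ring, a 1,2,4-oxadiazole, a nitrile or a plain methyl group would read on this same carbon, since two rings alone cannot mark the limits of what the position accepts. Also open, going by these compounds, is whether 1,3-oxazol-5-yl would give a similar result on the core of compound 1, where only 1-methyl-1H-imidazol-2-yl appears.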